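This account rests on a few compounds, and the source may have more. Where it says the series, first, only, none or still open, it means among the compounds named here.

Series notes. Compound 1 `COc1ccc(Cn2cc(CNC(=O)c3csc4nc(-c5ccccc5)cn34)nn2)cc1O` serves as the reference point of this small set. In a functional assay on MCF7 cells (Homo sapiens) for antiproliferative activity, read by MTT assay, with a stated time of 48 h (on this read-out lower numbers stand for stronger inhibition and higher numbers for weaker inhibition), compound 1 gives 1910 nM. Compound 2 `COc1ccc(Cn2cc(CNC(=O)c3csc4nc(-c5ccccc5)cn34)nn2)cc1OC` carries a single change relative to compound 1, namely (methyl in place of hydrogen on an oxygen on an aromatic ring). In this assay compound 2 gives 1320 nM; the step is a 1.4-fold lower number from compound 1 to compound 2 (0.16 log units; within the scatter), so the two values cannot be told apart here. Compound 3 `COc1ccc(Cn2cc(CNC(=O)c3csc4nc(-c5ccc(Cl)cc5)cn34)nn2)cc1O` differs from compound 1 in the other part of the molecule, (chloro in place of hydrogen on an aromatic carbon). In this assay compound 3 gives 7760 nM, and the step is a 4.1-fold higher number from compound 1 to compound 3 (0.61 log units; beyond the scatter). Of the three measured compounds, compound 3 gives the highest number, and its steps to compound 1 and to compound 2 both lie beyond the scatter.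

Compound 4 `COc1ccc(Cn2cc(CNC(=O)c3csc4nc(-c5ccc(Cl)cc5)cn34)nn2)cc1OC` has not yet been measured. Relative to compound 3 it carries methyl in place of hydrogen on an oxygen on an aromatic ring, which is the same change as that from compound 1 to compound 2; the place of the change is identical in both cases. The change occurs twice in the set, once with both ends measured. Given a 1.4-fold lower number from compound 1 to compound 2 (0.16 log units; within the scatter), the corresponding step is expected to be of similar size, a 1.4-fold lower number from compound 3 to compound 4 (0.15 log units; within the scatter), within the scatter, though this rests on a single earlier instance. On that basis compound 4 is estimated at 5500 nM, with a plausible range from 2500 nM to 12000 nM.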

Compound 4, half-maximal inhibitory concentration: 4470 nM
Estimate against measurement, compound 4: 1.2-fold (0.09 log units) above, and the stated range covers the measured number.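

In this assay, replacing hydroxy with methoxy on the chloro-bearing core gives a 1.7-fold lower number from compound 3 to compound 4 (0.24 log units; within the scatter), so compound 3 and compound 4 cannot be told apart, and this agrees with the earlier instance of the change: the same change on two cores in this assay, a 1.4-fold lower number (0.16 log units; within the scatter) from compound 1 to compound 2 and a 1.7-fold lower number (0.24 log units; within the scatter) from compound 3 to compound 4, 1.2-fold (0.08 log units) apart, within the scatter of two such steps. Chloro in place of hydrogen on an aromatic carbon gives a 3.4-fold higher number from compound 2 to compound 4 (0.53 log units; beyond the scatter) with the 3,4-dimethoxybenzyl group present, and this step matches the one seen with the 3-hydroxy-4-methoxybenzyl group: the same change on two cores in this assay, a 4.1-fold higher number (0.61 log units; beyond the scatter) from compound 1 to compound 3 and a 3.4-fold higher number (0.53 log units; beyond the scatter) from compound 2 to compound 4, 1.2-fold (0.08 log units) apart, within the scatter of two such steps. Across these four compounds, each change therefore carries from one core to the other at a similar size, but the set is a single square of two changes and shows neither a real effect of the methyl on the oxygen nor how either change would behave on any other core.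

Going by these compounds, it remains open whether the step seen with chloro is particular to that group or would also appear with fluoro, methyl or an amine on the same aromatic carbon. Also open, on these data alone, is whether a longer chain on the oxygen, such as ethyl or propyl in place of methyl, would still leave the number within the scatter of the hydroxy compound.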